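Removing a methoxy from a chalcone-derived core

The source may report more compounds than this note shows. Statements on the series, on what has been measured and on what is new or still open speak of the compounds shown alone.

Measured so far:
Compound 1 `COCOc1ccc(C(=O)/C=C/c2ccc(OCOC)c(CC=C(C)C)c2)c(O)c1` gives in an assay on isolated protein for inhibition of Aromatase (Homo sapiens) (a lower number here means a stronger inhibitor, a higher number a weaker inhibitor), a value that is a limit of the assay, > 242000 nM.
Compound 2 `COCOc1ccc(C(=O)/C=C/c2ccc(OC)c(CC=C(C)C)c2)c(O)c1` gives in this assay a value that is also a limit, > 261000 nM.
Compound 3 `COCOc1ccc2c(c1)OC(c1ccc(OCOC)c(CC=C(C)C)c1)CC2=O` gives in this assay 14000 nM.

Compound 1 and compound 2 differ by one change, (hydrogen in place of methoxy on a saturated chain carbon bound to an oxygen on an aromatic ring), but because the limit of > 242000 nM in this assay, at which 1 of the 3 values shown sits, and the limit of > 261000 nM in this assay, at which 1 of the 3 values shown sits, are limits rather than numbers, the step that the two limits leave unreadable from compound 1 to compound 2 cannot be sized. Compound 3 is built from the same atoms as compound 1 joined differently; the difference between the two cores is not broken down here. Compound 4 `COCOc1ccc(C2CC(=O)c3ccc(OC)cc3O2)cc1CC=C(C)C` carries the same change relative to compound 3, (hydrogen in place of methoxy on a saturated chain carbon bound to an oxygen on an aromatic ring), as compound 2 carries relative to compound 1. Since the step that the two limits leave unreadable from compound 1 to compound 2 from compound 1 gives no readable size, the expectation for the step of a 1.1-fold higher number from compound 3 to compound 4 (0.03 log units; within the scatter) rests only on the shared change and is taken as small. Compound 4 is therefore estimated at 15000 nM in this assay, within a range of 5000 nM to 45000 nM.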

Compound 4, half-maximal inhibitory concentration: 25100 nM
Estimate against measurement, compound 4: 1.7-fold (0.22 log units) below, and the stated range covers the measured number.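

In this assay, exchanging methoxymethoxy for methoxy on the core of compound 3 gives a 1.8-fold higher number from compound 3 to compound 4 (0.25 log units; within the scatter), so on this core the change does not stand out from the usual scatter. This does not show that the change carries over from one core to another, since the matching step on the core of compound 1 cannot be read, and compound 1 gives only a limit: the limit of > 242000 nM in this assay, at which 1 of the 4 values shown sits. Compound 2, the other half of that pair, also gives only a limit: the limit of > 261000 nM in this assay, at which 1 of the 4 values shown sits.

The compounds shown leave open whether a different group in the same place, such as a free hydroxyl or a longer chain like ethoxy, would shift the number in this assay beyond the scatter. They also leave open what happens when the second methoxymethoxy group, which compound 3 and compound 4 both keep, is exchanged in the same way.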